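Series notes: phenyl substituent change at the adenosine A3 read-out

A few compounds are considered here, and "the series" means these few. Any claim that something is new, unique, unknown or untested is made for them only; others in the source may bear on it.

Among the measured compounds shown here, compound 1 `CN1CCN(c2nc(-c3cccc(O)c3)nc3c2ncn3C)CC1` stands highest of the three numbers measured so far in an assay on cells for displacement of a labelled ligand from adenosine receptor A3 (Homo sapiens), read by scintillation counting and radioligand binding, with a stated time of 180 min, tested at 10 uM (on this read-out higher numbers stand for more inhibition at the one concentration tested (going by the name of the read-out) and lower numbers for less inhibition), where compound 1 gives 63.8%. Compound 3 `Cn1cnc2c(N3CCCCC3)nc(-c3cccc(O)c3)nc21` comes nearest, and in this assay compound 3 gives 49.1%, the step being a number 14.7 percentage points lower from compound 1 to compound 3 (beyond the scatter). Compound 2 `Cn1cnc2c(N3CCCCC3)nc(-c3cccc(O)c3O)nc21` lies furthest off, and in this assay compound 2 gives 33.7%; the step is a number 15.4 percentage points higher from compound 2 to compound 3 (beyond the scatter).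

Compound 4 `CN1CCN(c2nc(-c3cccc(Cl)c3)nc3c2ncn3C)CC1` differs from compound 1 in one place: chloro in place of hydroxy on an aromatic carbon. For the measured compounds named here, no measured step swaps hydroxy for chloro. Going by the values given here, the step that comes closest is the one from compound 2 to compound 3, which removes a different hydroxy from the same ring and raises inhibition by a modest amount. The step from compound 1 to compound 3 touches the other side of the core and does not bear on this change. With only that indirect hint, the expectation is for a step of a number 1.8 percentage points lower from compound 1 to compound 4 (within the scatter), within the scatter. The estimate for compound 4 in this assay is therefore 62%, expected to fall between 38% and 84%.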

Compound 4, a percentage reported as inhibition, at one concentration (the size of the read-out at that concentration, not a potency): 38.3%
Beside the measured number, compound 4's estimate is 23.7 percentage points above it, and the stated range covers the measured number.
By their numbers in this assay, from the lowest: compounds 2 and 4 (each within the scatter of the next); then compound 3; then compound 1.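

In this assay, this position on the phenyl ring proves sensitive to what it carries: chloro in place of hydroxy gives a number 25.5 percentage points lower from compound 1 to compound 4 (beyond the scatter). The earlier step on this ring, a number 15.4 percentage points higher from compound 2 to compound 3 (beyond the scatter), removed a different hydroxy and went upward, so hydroxy groups on this ring do not all act alike across compound 1, compound 2, compound 3 and compound 4, and the 3-hydroxyphenyl of compound 1 holds up better here than the 3-chlorophenyl. Nothing available accounts for the size or direction of this step.

From the compounds shown here alone, whether methoxy or an amine on this carbon would stay near compound 1 or fall toward compound 4 remains open. So does whether the same swap would give a step of similar size with the piperidin-1-yl group of compound 3.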